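This account rests on a few compounds, and the source may have more. Where it says the series, first, only, none or still open, it means among the compounds named here.

Compound 1, `CCOC(=O)/C=N/c1cnc(Nc2ccc(N3CCN(C)CC3)cc2)nc1NC1CCCC1`, gives 42300 nM in a functional assay on MCF7 cells (Homo sapiens) for antiproliferative activity, read by MTT assay; on this read-out higher numbers stand for weaker inhibition and lower numbers for stronger inhibition.
Compound 2, `CN1CCN(c2ccc(Nc3ncc(/N=C/c4ccccc4)c(NC4CCCC4)n3)cc2)CC1`, gives > 100000 nM in this assay, which is a limit of the assay and not a number.
Compound 3, `CCOC(=O)/C=N/c1cnc(Nc2ccc(N3CCN(C)CC3)cc2)nc1NC(C)C`, gives 12300 nM in this assay.

Compound 3 stands at the lowest of the two numbers shown; the nearest number belongs to compound 1, separated by the step of a 3.4-fold lower number from compound 1 to compound 3 (0.54 log units; beyond the scatter). Compound 4, `CC(C)Nc1nc(Nc2ccc(N3CCN(C)CC3)cc2)ncc1/N=C/c1ccccc1`, differs from compound 3 by phenyl in place of ethoxycarbonyl on a carbon with a double bond to nitrogen. The same exchange has been measured once, from compound 1 to compound 2: an at least 2.3-fold higher number from compound 1 to compound 2 (0.37 log units; beyond the scatter), and since compound 2 sits at the limit of > 100000 nM in this assay, at which 1 of the 3 values shown sits, the true step may be larger. The step from compound 3 to compound 4 is therefore expected to be a 3.3-fold higher number from compound 3 to compound 4 (0.51 log units; beyond the scatter), toward weaker inhibition. Compound 4 is estimated to give 40000 nM, within the range 15000 nM to 100000 nM.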

Compound 4, half-maximal inhibitory concentration: > 100000 nM
Compound 4 ended at the assay's limit; the forecaster's own chance of this, stated with the estimate: 30%; at least 2.5-fold (0.39 log units) between middle value and limit.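

Phenyl in place of ethoxycarbonyl, on a carbon with a double bond to nitrogen, also weakens inhibition when isopropyl replaces cyclopentyl on the core: an at least 8.1-fold higher number from compound 3 to compound 4 (0.91 log units; beyond the scatter). The loss therefore appears on both cores shown, yet its true size stays uncertain on each: the same change on two cores in this assay, an at least 2.3-fold higher number (0.37 log units; beyond the scatter) from compound 1 to compound 2 and an at least 8.1-fold higher number (0.91 log units; beyond the scatter) from compound 3 to compound 4; the limit leaves it open whether they differ. Both phenyl compounds end at a limit, so the step between them cannot be read, and any difference between isopropyl and cyclopentyl stays hidden there: the limit of > 100000 nM in this assay, at which 2 of the 4 values shown sit. Going by these compounds, how an amide or a carboxylic acid at this place would compare with ethoxycarbonyl remains open.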